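The source may hold more compounds than are shown below. What is called first, only, known or untested is meant among the compounds shown, and "the series" means these compounds.

Compound 3 `CC1=NN(C(=O)c2cc3ccccc3oc2=O)C(=O)C1CNc1ccc(Cl)cc1` carries a 4-chlorophenyl group on the amine nitrogen of the shared core, and in a functional assay on the whole organism for inhibition, with Rattus norvegicus as the target, read by paw edema, with stated times of 1 h and 6 h, at a dose of 0.03 mg/kg by the oral route (on this read-out lower numbers stand for less inhibition and higher numbers for more inhibition at the one dose given (going by the name of the read-out)), compound 3 gives 71.5%. Among the three measured numbers this is the second highest, yet the gap to compound 2 `CC1=NN(C(=O)c2cc3ccccc3oc2=O)C(=O)C1CNc1ccc(S(N)(=O)=O)cc1`, which in this assay gives 77.9%, lies within the scatter, as the step of a number 6.4 percentage points lower from compound 2 to compound 3 (within the scatter) shows. Compound 1 `CC1=NN(C(=O)c2cc3ccccc3oc2=O)C(=O)C1CNc1ccccn1` gives 50.3% in this assay, and the two steps from it, a number 27.6 percentage points higher from compound 1 to compound 2 (beyond the scatter) and a number 21.2 percentage points higher from compound 1 to compound 3 (beyond the scatter), are the only ones beyond the scatter.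

Compound 4 `CC1=NN(C(=O)c2cc3ccccc3oc2=O)C(=O)C1CNc1ccc(O)c(C(=O)O)c1` differs from compound 3 at the same place: 3-carboxy-4-hydroxyphenyl in place of 4-chlorophenyl on an amine nitrogen. The step that bears on this change is the swap of one ring substituent for another, a number 6.4 percentage points lower from compound 2 to compound 3 (within the scatter), which stayed within the scatter. Within the data shown here, no measured compound carries a carboxy or hydroxy group, so the expectation rests on that one step alone. For compound 4 a value of 70% is therefore estimated in this assay, within 52% to 86%. The expected step from compound 3 is a number 1.5 percentage points lower from compound 3 to compound 4 (within the scatter), not beyond the scatter.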

Compound 4, a percentage reported as inhibition, in the whole organism at one dose (the size of the read-out at that dose, not a potency): 50.9%
Beside the measured number, compound 4's estimate is 19.1 percentage points above it; measured number outside the range, below it.
By their numbers in this assay, from the lowest: compounds 1 and 4 (each within the scatter of the next); then compounds 3 and 2 (each within the scatter of the next).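

At this amine nitrogen the earlier phenyl compounds stood close together, but in this assay the step of a number 20.6 percentage points lower from compound 3 to compound 4 (beyond the scatter) shows that a phenyl ring here does not by itself keep the number high, and that what the ring carries counts. The step of a number 27 percentage points lower from compound 2 to compound 4 (beyond the scatter) points the same way, while the step of a number 0.6 percentage points higher from compound 1 to compound 4 (within the scatter) places this phenyl compound level with the pyridin-2-yl compound, so the earlier gap between phenyl and pyridin-2-yl does not apply to every phenyl ring. Nothing measured here explains this difference.

Compound 4 carries the carboxy and hydroxy groups together, which leaves open how much of the step belongs to each of them. Also open, going by these compounds, is how a phenyl ring bearing a single methoxy group or a single amine would read at this nitrogen.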